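From trifluoromethyl to difluoromethyl on compound 3

The compounds below may be only part of what the source reports. "The series", "measured", "known", "first", "only" and "open" are said of these compounds alone.

- Compound 1 (`CCC(=O)NS(=O)(=O)c1ccc(-n2nc(C(F)(F)F)cc2-c2ccc(SC)cc2)cc1COC(=O)CC`): 38 mg/kg; 40 mg/kg (2 entries)
- Compound 2 (`CCC(=O)NS(=O)(=O)c1ccc(-n2nc(C(F)(F)F)cc2-c2ccc(SC)cc2)cc1CO`): 36 mg/kg
- Compound 3 (`NS(=O)(=O)c1ccc(-n2nc(C(F)(F)F)cc2-c2ccc(Br)cc2)cc1CO`): 35 mg/kg

The three compounds were tested in a functional assay on the whole organism (strain Wistar) with Rattus norvegicus as the target, read by paw edema, at a dose of 30 mg/kg by the oral route (on this read-out lower numbers stand for an effect already at smaller amounts and higher numbers for an effect only at larger amounts of compound), and their numbers lie close together. Compound 3 gives 35 mg/kg and compound 2 gives 36 mg/kg, which places the two within the usual scatter of each other. Compound 1 has two entries (the several entries of compound 1 in this assay, 38 mg/kg; 40 mg/kg (2 entries)) that also sit close together and in the same range. The numbers therefore set compound 3 level with its neighbours rather than apart from them.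

Compound 4 (`NS(=O)(=O)c1ccc(-n2nc(C(F)F)cc2-c2ccc(Br)cc2)cc1CO`) has not yet been measured. It differs from compound 3 in one place (hydrogen in place of fluoro on a saturated chain carbon bound to an aromatic carbon and two fluorine atoms): hydrogen in place of fluoro on a saturated chain carbon bound to an aromatic carbon and two fluorine atoms, so that trifluoromethyl becomes difluoromethyl. Among the measured compounds shown here, no measured pair in this small set shows this change, so the expectation has to start from compound 3 (35 mg/kg) alone. The expected step is a 1.1-fold higher number from compound 3 to compound 4 (0.04 log units; within the scatter) and it is not expected to go beyond the scatter in either direction. For the measured compounds named here, the range is kept wide because no measured step supports it. Compound 4 is expected at 38 mg/kg (estimated range 18 mg/kg to 80 mg/kg).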

Compound 4, dose for half-maximal effect: 42 mg/kg
Estimate against measurement, compound 4: 1.1-fold (0.04 log units) below; measured number inside the range.
By their numbers in this assay, from the lowest: compounds 3, 2 and 4 (each within the scatter of the next).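

Among the compounds shown here, the step of a 1.2-fold higher number from compound 3 to compound 4 (0.08 log units; within the scatter) is the only reading in this assay of a change at this place, the saturated chain carbon bound to an aromatic carbon and two fluorine atoms. Compounds 1, 2 and 3 all carry trifluoromethyl and could say nothing about this group, whereas compound 4 shows that, with hydrogen in place of one fluoro, the number stays within the scatter of that of compound 3, and that the full trifluoromethyl group is not required for a number in this range. The closeness of this pair can be set against the agreement of repeated entries in the same read-out, which one compound shows: the several entries of compound 1 in this assay, 38 mg/kg; 40 mg/kg (2 entries)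

This remains a single pair on a single core, and it leaves open whether the same change would read alike on the core of compound 2. Also open, on these data alone, is how a fluoromethyl, a plain methyl, an ethyl or a nitrile at this place would compare in this assay with the trifluoromethyl of compound 3 and the difluoromethyl of compound 4.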